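Serum protein binding: tert-butyl ketone in the hydroxyethoxy series

The compounds below may be only part of what the source reports. "The series", "measured", "known", "first", "only" and "open" are said of these compounds alone.

Compound 2 `COc1ccc(C(=O)C2=C(O)C(=O)N(c3ccc(-c4ccon4)cc3)C2c2ccccc2OCCO)cc1` stands highest of the two numbers in an ADME assay on the whole organism (serum, Rattus norvegicus) for protein binding (on this read-out higher numbers stand for a larger free fraction and lower numbers for a smaller free fraction), with 0.003, and the nearest value, that of compound 1 `COc1ccccc1C1C(C(=O)C(C)(C)C)=C(O)C(=O)N1c1ccc(-c2ccon2)cc1`, is 0.002, a difference within the scatter. Compound 3 `CC(C)(C)C(=O)C1=C(O)C(=O)N(c2ccc(-c3ccon3)cc2)C1c1ccccc1OCCO` carries tert-butyl in place of 4-methoxyphenyl on a carbonyl carbon, described as tert-butyl in place of 4-methoxyphenyl on a carbonyl carbon. Among the compounds with values here, no measured step covers this change, and nothing in the two measured values points beyond the scatter. The step of a 1.2-fold lower number from compound 2 to compound 3 (0.08 log units; within the scatter) is expected to stay within the scatter. Compound 3 is expected to give 0.0025 in this assay, with a range of 0.001 to 0.006.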

Compound 3, unbound fraction: 0.012
Compound 3: the middle estimate sits 4.8-fold (0.68 log units) below what was measured; measured number above the stated range.
By their numbers in this assay, from the lowest: compounds 1 and 2 (each within the scatter of the next); then compound 3.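

With the hydroxymethyl held in place, the carbonyl substituent proves able to shift the free fraction in this assay: tert-butyl in place of 4-methoxyphenyl gives a 4.0-fold higher number from compound 2 to compound 3 (0.60 log units; beyond the scatter). With tert-butyl held in place, hydroxymethyl in place of hydrogen on the saturated chain carbon gives a 6.0-fold higher number from compound 1 to compound 3 (0.78 log units; beyond the scatter), so both single steps to compound 3 lie beyond the scatter. Nothing available explains either step.

Open, going by these compounds, is whether an isopropyl or a cyclohexyl on the carbonyl carbon would behave like tert-butyl. Also open, on these data alone, is how a carboxylic acid or an amine in place of the hydroxymethyl would read.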